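The source may hold more compounds than are shown below. What is called first, only, known or untested is meant among the compounds shown, and "the series" means these compounds.

Measured so far in an ADME assay for permeability, using PAMPA; on this read-out higher numbers stand for higher permeability and lower numbers for lower permeability:

Compound 1 `COc1ccc(C(Cc2ccc(-c3nc(C(=O)O)cs3)cc2)c2nc(-c3cccc(F)c3)no2)cc1` gives 6 10^-6 cm/s.
Compound 2 `O=C(O)c1cc(-c2ccc(CC(C(=O)c3ccccc3)c3ccccc3)cc2)no1` gives 103 10^-6 cm/s.
Compound 3 `O=C(O)c1cc(-c2ccc(CC(c3ccccc3)c3nc(-c4ccccc4)no3)cc2)no1` gives 45 10^-6 cm/s.

Compound 1 stands lowest of the three numbers in this assay. Compound 3 is its nearest neighbour, and compound 2 is the furthest; both gaps lie beyond the usual scatter of repeated measurements.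

Compound 4 `O=C(O)c1csc(-c2ccc(CC(c3ccc(F)cc3)c3nc(-c4cccc(F)c4)no3)cc2)n1` has not yet been measured. It differs from compound 1 in one place: fluoro in place of methoxy on an aromatic carbon, that is, on an aromatic carbon of a six-membered aromatic ring of carbon only, para to a large group, so that 4-methoxyphenyl becomes 4-fluorophenyl.

Going by the values given here, only one step between measured compounds is available, a 2.3-fold lower number from compound 2 to compound 3 (0.36 log units; beyond the scatter). Among the compounds with values here, that step concerns a different part of the molecule, and no measured pair shows a methoxy-to-fluoro exchange, so no step bears directly on the change to compound 4. Compound 4 is therefore estimated to sit close to compound 1, with the step of a 1.3-fold higher number from compound 1 to compound 4 (0.12 log units; within the scatter) expected to stay within the scatter. The estimate for compound 4 is 8 10^-6 cm/s, with a range from 3 10^-6 cm/s to 20 10^-6 cm/s.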

Compound 4, apparent permeability: 10 10^-6 cm/s
Beside the measured number, compound 4's estimate is 1.3-fold (0.10 log units) below it; the range from low to high includes it.
By their numbers in this assay, from the lowest: compounds 1 and 4 (each within the scatter of the next); then compound 3; then compound 2.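

In this assay, fluoro in place of methoxy on an aromatic carbon, para to a large group, gives a 1.7-fold higher number from compound 1 to compound 4 (0.22 log units; within the scatter). Going by these compounds alone, this is the first reading at this position, as the earlier step concerned a different part of the molecule, and it shows that this exchange, which takes out one hydrogen-bond acceptor and one heavy atom, leaves the read-out within the usual scatter. No measurement at hand offers an explanation for this result.

Going by these compounds, it remains open whether a different group on this aromatic carbon, such as an amine or a carboxylic acid, would shift the number beyond the scatter. On these data alone, it is also open whether 4-methoxyphenyl and 4-fluorophenyl would read alike on the core of compound 3.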